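From Hydroxy to Chloro: Compound 3 to Compound 4

The compounds below may be only part of what the source reports. "The series", "measured", "known", "first", "only" and "open" are said of these compounds alone.

Compound 1, `CSc1cnc2ccccc2c1[Se]CC#CCO`: 0.5 ug/mL
Compound 2, `CCOC(=O)OCC#CCSc1c(SC)cnc2ccccc12`: 13.2 ug/mL
Compound 3, `CSc1cnc2ccccc2c1SCC#CCO`: 2.3 ug/mL

In a functional assay on CCRF-CEM cells (Homo sapiens) for antiproliferative activity, with a stated time of 72 h (a higher number here means a weaker inhibitor, a lower number a stronger inhibitor), compound 3 gives 2.3 ug/mL, the second highest of the three numbers. The nearest is compound 1 with 0.5 ug/mL, the step being a 4.6-fold higher number from compound 1 to compound 3 (0.66 log units; beyond the scatter). The furthest is compound 2 with 13.2 ug/mL, the step being a 5.7-fold lower number from compound 2 to compound 3 (0.76 log units; beyond the scatter).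

Compound 4, `CSc1cnc2ccccc2c1SCC#CCCl`, differs from compound 3 in one place: chloro in place of hydroxy on a saturated chain carbon bound to a triple-bonded carbon. Among the compounds with values here, no measured step makes this exact change. The step of a 4.6-fold higher number from compound 1 to compound 3 (0.66 log units; beyond the scatter) concerns the chalcogen on the aromatic carbon and does not bear on the hydroxy. The step of a 5.7-fold lower number from compound 2 to compound 3 (0.76 log units; beyond the scatter) does touch the same oxygen: removing the ethoxycarbonyl from it lowered the number, so altering the hydroxy has moved this assay before. On that basis a modest rise in the number is expected for compound 4, the step of a 2.0-fold higher number from compound 3 to compound 4 (0.29 log units; within the scatter), though a result within the scatter would not surprise. Compound 4 is estimated at 4.5 ug/mL, between 1.5 ug/mL and 14 ug/mL.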

Compound 4, concentration for 50% inhibition: 2.5 ug/mL
Estimate against measurement, compound 4: 1.8-fold (0.26 log units) above, and the stated range covers the measured number.
By their numbers in this assay, from the lowest: compound 1; then compounds 3 and 4 (each within the scatter of the next); then compound 2.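

In this assay, chloro in place of hydroxy on the saturated chain carbon bound to a triple-bonded carbon stays within the scatter (a 1.1-fold higher number from compound 3 to compound 4 (0.04 log units; within the scatter)), so at this position the hydroxy, with its hydrogen-bond donor, is not needed to keep the number of compound 3. Chloro in place of (ethoxycarbonyl)oxy gives a step beyond the scatter (a 5.3-fold lower number from compound 2 to compound 4 (0.72 log units; beyond the scatter)), so among compounds 2, 3 and 4 only the (ethoxycarbonyl)oxy end stands apart. Compound 1 remains apart from the chloro compound as well (a 5.0-fold higher number from compound 1 to compound 4 (0.70 log units; beyond the scatter)), so chloro does not close the gap to the selenium compound.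

Nothing available explains why hydroxy and chloro read alike here. On these data alone, whether an amine or a longer chain at this end would read the same, and how chloro behaves alongside selenium, stays open.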